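Replacing 4-fluorophenoxy with (4-fluorophenyl)carbonyl: working notes

The source may hold more compounds than are shown below. What is called first, only, known or untested is meant among the compounds shown, and "the series" means these compounds.

Measured in a functional assay on NCI-H460 cells (Homo sapiens) for cytotoxicity, read by MTT assay, with a stated time of 72 h; a lower number here means a stronger inhibitor, a higher number a weaker inhibitor:
- compound 1 `CC(C)c1[nH]cnc1/C=c1\[nH]c(=O)/c(=C/c2cccc(C(=O)c3ccc(F)cc3)c2)[nH]c1=O` gives 3.2 nM 
- compound 2 `Cc1[nH]cnc1/C=c1\[nH]c(=O)/c(=C/c2cccc(Oc3ccc(F)cc3)c2)[nH]c1=O` gives 47.6 nM 

Of these two, compound 2 holds the higher number in this assay and so reads as the weaker inhibitor, and its gap to compound 1 lies beyond the scatter of repeated measurements. The next compound to read is compound 3 `Cc1[nH]cnc1/C=c1\[nH]c(=O)/c(=C/c2cccc(C(=O)c3ccc(F)cc3)c2)[nH]c1=O`, which has (4-fluorophenyl)carbonyl in place of 4-fluorophenoxy on an aromatic carbon and keeps the rest of compound 2 unchanged. Among the compounds with values here, no measured pair isolates this change, so its size cannot be read directly from the data. Within the data shown here, the only guide is compound 1 (3.2 nM), the one measured point with a lower number than compound 2 (47.6 nM). A moderate move towards a lower number is expected in this assay, estimated as a 3.4-fold lower number from compound 2 to compound 3 (0.53 log units; beyond the scatter) and likely beyond the scatter, though with wide uncertainty. For compound 3 the estimated value is 14 nM (expected range 4 nM to 50 nM).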

Compound 3, half-maximal inhibitory concentration: 15.9 nM
For compound 3 the middle estimate is 1.1-fold (0.06 log units) below the measured one; the measured number falls inside the stated range.
By their numbers in this assay, from the lowest: compound 1; then compound 3; then compound 2.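

Read in this assay, the exchange of 4-fluorophenoxy for (4-fluorophenyl)carbonyl, on an aromatic carbon meta to a large group and with the rest of the molecule held constant, gives a 3.0-fold lower number from compound 2 to compound 3 (0.48 log units; beyond the scatter), so this position responds to the change and the response lies beyond the scatter. With (4-fluorophenyl)carbonyl kept in place, methyl in place of isopropyl on an aromatic carbon gives a 5.0-fold higher number from compound 1 to compound 3 (0.70 log units; beyond the scatter), which shows that the series also responds at this second site, with the lower number on the isopropyl side. No measurement bearing on either step is available, so the data give the size and direction of these changes but no explanation for them.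

It remains open whether the step to (4-fluorophenyl)carbonyl keeps its size with isopropyl on the other site, as the shown pair for this change carries methyl. Also open, on these data alone, is how the series would read with a methylene or amine link in place of the carbonyl, or with ethyl in place of methyl.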